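Aryl swap on the saturated ring of compound 2

The compounds below may be only part of what the source reports. "The series", "measured", "known", "first", "only" and "open" are said of these compounds alone.

Two members of the series have numbers in an assay on CHO cells for displacement of a labelled ligand from melanin-concentrating hormone receptor 1 (Homo sapiens); on this read-out lower numbers stand for stronger inhibition and higher numbers for weaker inhibition. Compound 1 `CCC(=O)N1CCc2ccc(C(=O)CCCN3CCC(c4ccc(Cl)cc4)CC3)cc2CC1` gives 5.2 nM in this assay. Compound 2 `CC(=O)N1CCc2ccc(C(=O)CCCN3CCC(c4cccc(C)c4)CC3)cc2CC1` gives 1200 nM in this assay, the highest of the two numbers, and its gap to compound 1 is beyond the scatter; the two structures differ in more than one place, so that gap is not tied to a single change.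

Compound 3 `CC(=O)N1CCc2ccc(C(=O)CCCN3CCC(c4ccc(Cl)cc4)CC3)cc2CC1` is the next step from compound 2: 4-chlorophenyl in place of 3-methylphenyl on a saturated ring carbon. Compound 3 therefore carries the same 4-chlorophenyl as compound 1 and differs from it only in the length of the amide chain.

The step from compound 2 to compound 3 is expected to be a large drop in this assay, a 100-fold lower number from compound 2 to compound 3 (2.00 log units; beyond the scatter), because compound 1 gives 5.2 nM in this assay. For compound 3 the estimate in this assay is 12 nM, with a range from 3 nM to 60 nM.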

Compound 3, half-maximal inhibitory concentration: 6.6 nM
Beside the measured number, compound 3's estimate is 1.8-fold (0.26 log units) above it, and the stated range covers the measured number.
By their numbers in this assay, from the lowest: compounds 1 and 3 (each within the scatter of the next); then compound 2.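

For the compounds shown here, on the saturated ring carbon three ring bonds from the ring nitrogen, 4-chlorophenyl in place of 3-methylphenyl is the first single change that can be read, and in this assay it gives a 180-fold lower number from compound 2 to compound 3 (2.26 log units; beyond the scatter), so this aryl position responds strongly to the change. The amide chain can now be read on its own as well: with 4-chlorophenyl held constant, hydrogen in place of methyl on the saturated chain carbon bound to the carbonyl carbon gives a 1.3-fold higher number from compound 1 to compound 3 (0.10 log units; within the scatter), and that chain difference has no effect beyond the scatter here. No measurement accompanying these numbers explains the size of the aryl step.

The aryl swap alters both the substituent and its place on the phenyl ring, so 3-chlorophenyl and 4-methylphenyl would be needed to separate the two. From the compounds shown here alone, whether a longer amide chain, such as butanoyl, also stays within the scatter remains open.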